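Swapping Azido for Dimethylamino on a Shared Nucleoside Core

The source may report more compounds than this note shows. Statements on the series, on what has been measured and on what is new or still open speak of the compounds shown alone.

Compound 1 `[N-]=[N+]=Nc1nccc2c1ncn2[C@H]1C[C@H](O)[C@@H](CO)O1` was tested in a functional assay (Homo sapiens) for inhibition of Nucleic Acid, tested at 100 uM (on this read-out lower numbers stand for less inhibition and higher numbers for more inhibition at the one concentration tested (going by the name of the read-out)), where compound 1 gave 4%. Compound 2 `OC[C@H]1OC(n2cnc3c(Nc4ccccc4)nccc32)[C@H](O)[C@@H]1O`, which carries the same fused core with a different sugar and substituent, gave 4% in this assay. The two values sit level at the digits printed, within the scatter, so compound 1 stands alongside compound 2 with nothing separating them. Going by the values given here, no pair of measured compounds differing in a single place is available, so no measured step guides the next move. Compound 3 `CN(C)c1nccc2c1ncn2[C@H]1C[C@H](O)[C@@H](CO)O1` has not yet been measured. It differs from compound 1 thus: dimethylamino in place of azido on an aromatic carbon. The step from compound 1 to compound 3 in this assay is expected to be small, a number 1 percentage points higher from compound 1 to compound 3 (within the scatter), not beyond the scatter, because compound 1 gives 4% and the other measured value is equally low. Compound 3 is therefore expected to give an estimated 5% in this assay, within a range from -5% to 20%.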

Compound 3, a percentage reported as inhibition, at one concentration (the size of the read-out at that concentration, not a potency): 0%
Beside the measured number, compound 3's estimate is 5 percentage points above it; the range from low to high includes it.
By their numbers in this assay, from the lowest: compounds 3, 1 and 2 (each within the scatter of the next).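

Dimethylamino in place of azido on an aromatic carbon, next to the ring nitrogen, gives a number 4 percentage points lower from compound 1 to compound 3 (within the scatter) in this assay, and this is the only comparison here in which two compounds differ in one place. At this position, then, the two groups cannot be told apart on this read-out, even though the atoms of the group that enters are not those of the group that leaves. Nothing available bears on why the two groups read alike.

On these data alone, whether a primary amine, a carboxylic acid or a longer chain in that same place would move the read-out beyond the scatter remains open. Also open, as far as these compounds go, is what the sugar alone contributes, as the sugar of compound 2 is not seen on a core otherwise matching compound 1 or compound 3.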